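The compounds below may be only part of what the source reports. "The series", "measured", "known", "first", "only" and "open" are said of these compounds alone.

Compound 1, `Brc1ccc(-c2csnn2)cc1`: 68100 nM
Compound 2, `C/C(=N\NC(=O)COc1cccc2cccnc12)c1ccc(Cl)cc1`: > 100000 nM
Compound 3, `C/C(=N\NC(=O)COc1cccc2cccnc12)c1ccc(Br)cc1`: > 100000 nM

In an ADME assay on MCF7 cells (Homo sapiens) for cytotoxicity, read by MTT assay, with a stated time of 48 h (on this read-out lower numbers stand for stronger inhibition and higher numbers for weaker inhibition), compound 1 gives 68100 nM. For compound 2 the assay reports only a limit, > 100000 nM. For compound 3 the assay likewise reports only a limit, > 100000 nM. Compound 3 and compound 2 differ in one place, (chloro in place of bromo on an aromatic carbon), and the step that the two limits leave unreadable from compound 3 to compound 2, since both values sit at the limit of > 100000 nM in this assay, at which 2 of the 3 values shown sit. The difference between the core of compound 1 and the core of compound 3 is not broken down here.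

Compound 4, `Clc1ccc(-c2csnn2)cc1`, is not yet measured. It differs from compound 1 by chloro in place of bromo on an aromatic carbon, the same kind of change as that from compound 3 to compound 2, though here the place is para to a group of 5 heavy atoms rather than para to a large group. Because a step that the two limits leave unreadable from compound 3 to compound 2 has no readable size, the expectation rests on compound 1 alone, whose value is 68100 nM. The expected step is a 1.2-fold higher number from compound 1 to compound 4 (0.07 log units; within the scatter). For compound 4 the estimated value in this assay is 80000 nM, expected to lie between 35000 nM and 200000 nM.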

Compound 4, half-maximal inhibitory concentration: > 100000 nM
Compound 4: only a limit was reported; the forecaster's own chance of this, stated with the estimate: 30%; middle value at least 1.2-fold (0.09 log units) from the limit.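

In this assay the replacement of bromo by chloro on an aromatic carbon gives an at least 1.4-fold higher number from compound 1 to compound 4 (0.16 log units; that floor lies within the scatter), a floor set by an assay limit rather than a measured size. The same change on the core of compound 3 cannot be read, so the data neither show that the change carries from one core to the other nor show that it does not. Most of the values in this series offer no number to compare: the limit of > 100000 nM in this assay, at which 3 of the 4 values shown sit.

What the compounds shown leave open is how an amine or a carboxylic acid in place of the bromo would read on the core of compound 1. Also open, as far as these compounds go, is whether any such group would bring the core of compound 3 to a readable value.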